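Vero cytotoxicity: thiophene replacing methoxyphenyl at the ring carbon

The source may report more compounds than this note shows. Statements on the series, on what has been measured and on what is new or still open speak of the compounds shown alone.

The series shares one core and differs only in the group on the saturated ring carbon. Compound 1 `CC1=C(C(=O)Nc2ccccc2Cl)C(c2ccc(Cl)cc2)NC(=O)N1` is reported in an ADME assay on Vero cells (Chlorocebus sabaeus) for cytotoxicity, read by XTT assay, with a stated time of 72 h (a higher number here means that more compound is tolerated, a lower number that less compound is tolerated), as "non-toxic" (no number reported), with no number attached. Compound 2 `CC1=C(C(=O)Nc2ccccc2Cl)C(c2ccc(Br)cc2)NC(=O)N1` in this assay reaches only the limit > 100000 nM. Compound 3 `COc1ccc(C2NC(=O)NC(C)=C2C(=O)Nc2ccccc2Cl)cc1` likewise gives only the limit > 100000 nM in this assay. The step that the two limits leave unreadable from compound 2 to compound 3 stays unreadable because both of its ends sit at the limit of > 100000 nM in this assay, at which 2 of the 3 values shown sit. On the numbers shown, compound 3 stands at a limit, beside one further limit and one entry without a number; no compound in the series has a measured number in this assay. Compound 4 `CC1=C(C(=O)Nc2ccccc2Cl)C(c2cccs2)NC(=O)N1` differs from compound 3 by thiophen-2-yl in place of 4-methoxyphenyl on a saturated ring carbon. For the measured compounds named here, no measured step bears directly on this change, and the single counted step is unreadable, so no size of step beyond the scatter can be drawn from the data. Compound 4 is expected to sit again at the limit, estimated at 150000 nM within 60000 nM to 400000 nM. The expected step that the limit leaves unreadable from compound 3 to compound 4 is thus none beyond the scatter.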

Compound 4, half-maximal cytotoxic concentration: > 100000 nM
Compound 4: only a limit was reported; the forecaster's own chance of this, stated with the estimate: 85%; the middle value is on the limit's open side.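

The steps among compound 2, compound 3 and compound 4 cannot be read, as each compound gives only a limit in this assay: the limit of > 100000 nM in this assay, at which 3 of the 4 values shown sit.

The compounds shown leave open whether any group on the saturated ring carbon gives a cytotoxic concentration within the range of this assay.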